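Fluoro Added to the Core of Compound 1

This account rests on a few compounds, and the source may have more. Where it says the series, first, only, none or still open, it means among the compounds named here.

Compound 1 `CC(C)COc1ncc(-c2cn(C)c3cc(C(=O)NS(C)(=O)=O)ccc23)cc1Cl`: 66%
Compound 2 `Cn1cc(-c2ccc(C(F)F)cc2)c2cc(F)c(C(=O)NS(=O)(=O)C3CC3)cc21`: 82%
Compound 3 `CC(C)COc1ccc(-c2nn(C)c3cc(C(=O)NS(=O)(=O)C4CC4)c(F)cc23)cn1`: 88%

In an ADME assay on microsomes from liver (Rattus norvegicus) for metabolic stability, with a stated time of 10 min, tested at 0.5 uM (a lower number here means that less of the compound is left, a higher number that more of the compound is left), compound 1 gives 66%, the lowest of the three numbers. Compound 2 gives 82% and compound 3 gives 88%; both lie beyond the usual scatter above compound 1, but each differs from compound 1 in several places, so no single step can be read from them.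

Compound 4 `CC(C)COc1ncc(-c2cn(C)c3cc(C(=O)NS(C)(=O)=O)c(F)cc23)cc1Cl` differs from compound 1 in one place: fluoro in place of hydrogen on an aromatic carbon. Among the measured compounds shown here, no step between measured compounds shows what this change does. Compound 4 is therefore expected to sit close to compound 1, with at most a small upward step of a number 7 percentage points higher from compound 1 to compound 4 (within the scatter) in this assay. The estimate for compound 4 is 73%, within 58% to 88%.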

Compound 4, percent of the compound remaining: 85%
The estimate for compound 4 lay 12 percentage points below the measured number, and the stated range covers the measured number.
By their numbers in this assay, from the lowest: compound 1; then compounds 2, 4 and 3 (each within the scatter of the next).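

Fluoro in place of hydrogen on this aromatic carbon, ortho to a (methylsulfonyl)carbamoyl group, gives a number 19 percentage points higher from compound 1 to compound 4 (beyond the scatter) in this assay. Among the compounds shown here, this is the first step that can be read from a single change, and it shows that this one position, with one added fluorine atom, can by itself move the number beyond the scatter. Nothing measured here accounts for the step.

On these data alone, whether chloro or a methoxy group on the same carbon would give a similar step remains open. So does whether fluoro gives this step when a cyclopropylsulfonyl group replaces the methylsulfonyl group.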